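This account rests on a few compounds, and the source may have more. Where it says the series, first, only, none or still open, it means among the compounds named here.

Compound 1, `C=C[C@@](C)(/C=C/c1ccc(O)c(/C=C(\C)C(=O)OCC)c1)CCC=C(C)C`: in an ADME assay on HEK293 cells (Homo sapiens) for cytotoxicity, with a stated time of 72 h (a lower number here means that less compound is needed, a higher number that more compound is needed for the effect), compound 1 gives > 36600 nM, which is a limit of the assay rather than a number.
Compound 2, `C=C[C@@](C)(/C=C/c1ccc(Nc2ccc(OC)c(F)c2)cc1)CCC=C(C)C`: in this assay compound 2 gives > 36600 nM, again a limit.
Compound 3, `C=C[C@@](C)(/C=C/c1ccc(Nc2ccc(F)c(F)c2)cc1)CCC=C(C)C`: in this assay compound 3 gives > 36600 nM, also a limit.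

Compound 3 therefore stands only at a limit in this assay, with no number of its own. Within the data shown here, the one step that has been measured, a step that the two limits leave unreadable from compound 2 to compound 3, cannot be read in size, because of the limit of > 36600 nM in this assay, at which 3 of the 3 values shown sit.

Compound 4, `C=C[C@@](C)(/C=C/c1ccc(-c2ccc(Cl)c(Cl)c2)cc1)CCC=C(C)C`, carries 3,4-dichlorophenyl in place of (3,4-difluorophenyl)amino on an aromatic carbon.

Among the measured compounds shown here, no measured step bears on this change in a readable way. For the measured compounds named here, what is known is that every compound so far sits at the limit in this assay, because of the limit of > 36600 nM in this assay, at which 3 of the 3 values shown sit. Compound 4 is thus expected to stay near that limit as well, with the step that the limit leaves unreadable from compound 3 to compound 4 estimated to lie within the scatter. The expected value for compound 4 in this assay is 50000 nM, with a range from 20000 nM to 200000 nM.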

Compound 4, half-maximal effective concentration: > 36600 nM
Compound 4 was reported as a limit (the forecaster's own chance of this, stated with the estimate: 80%); the middle value lies beyond the limit too.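

The size of the step from compound 3 to compound 4 cannot be read, because both sit at a limit in this assay: the limit of > 36600 nM in this assay, at which 4 of the 4 values shown sit.

The compounds shown leave open how much of any of them is needed for the effect, and whether swapping (3,4-difluorophenyl)amino for 3,4-dichlorophenyl changes that amount.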